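The compounds below may be only part of what the source reports. "The series", "measured", "known", "first", "only" and "open" are said of these compounds alone.

Compound 1, with the structure `CCCCc1ccc2[nH]c(-c3ccc(C(F)(F)F)cc3)c(C=O)c2c1`, and compound 2, with the structure `CCCCc1ccc2[nH]c(-c3ccc(CC)cc3)c(C=O)c2c1`, share a core and differ only in that one change, (ethyl in place of trifluoromethyl on an aromatic carbon). In a functional assay on MDA-MB-231 cells (Homo sapiens) for antiproliferative activity, with a stated time of 4 days (a lower number here means a stronger inhibitor, a higher number a weaker inhibitor), compound 1 gives 33 nM, and compound 2 gives 27 nM; the step is a 1.2-fold lower number from compound 1 to compound 2 (0.09 log units; within the scatter), so the two numbers cannot be told apart.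

Compound 3, with the structure `CCCCc1ccc2[nH]c(-c3ccc(C(F)(F)F)cc3)c(/C=N/NC(=O)c3cccnc3)c2c1`, carries the same group as compound 1 on the pendant ring but differs from it in the core: a group of 11 heavy atoms (7 carbon, 3 nitrogen, 1 oxygen; one six-membered aromatic ring with 1 hetero atom) in place of a group of 2 heavy atoms (1 carbon, 1 oxygen; no ring), on an aromatic carbon. In this assay compound 3 gives 97 nM, a step of a 2.9-fold higher number from compound 1 to compound 3 (0.47 log units; beyond the scatter). Among the three measured compounds, compound 3 has the highest number.

Compound 4, with the structure `CCCCc1ccc2[nH]c(-c3ccc(CC)cc3)c(/C=N/NC(=O)c3cccnc3)c2c1`, has not been measured. It stands to compound 3 as compound 2 stands to compound 1: the change is ethyl in place of trifluoromethyl on an aromatic carbon, and the place where it is made reads the same in both pairs, so it is the same change, made here on the core of compound 3 rather than that of compound 1.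

The step from compound 3 to compound 4 is expected to be small, a 1.2-fold lower number from compound 3 to compound 4 (0.08 log units; within the scatter), because the same change gave a 1.2-fold lower number from compound 1 to compound 2 (0.09 log units; within the scatter). Among the measured compounds shown here, the single earlier instance is the only footing for this, and it rests on a different core. Compound 4 is estimated to give 80 nM in this assay, between 40 nM and 160 nM.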

Compound 4, half-maximal inhibitory concentration: 53 nM
Compound 4: middle estimate off by 1.5-fold (0.18 log units), on the high side, and the stated range covers the measured number.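

On the core of compound 3, ethyl in place of trifluoromethyl gives, in this assay, a step of a 1.8-fold lower number from compound 3 to compound 4 (0.26 log units; within the scatter), so on this core, as on the core of compound 1, the two groups cannot be told apart by this read-out. Set beside the earlier step, the change carries from one core to the other with no difference that can be resolved: the same change on two cores in this assay, a 1.2-fold lower number (0.09 log units; within the scatter) from compound 1 to compound 2 and a 1.8-fold lower number (0.26 log units; within the scatter) from compound 3 to compound 4, 1.5-fold (0.18 log units) apart, within the scatter of two such steps This shows only that the swap from 4-(trifluoromethyl)phenyl to 4-ethylphenyl leaves the number within the scatter on these two cores, and with just two pairs, in a single assay, it does not show that the same would hold on any further core in the series.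

The compounds shown leave open what other groups would do in the same place on the pendant ring, such as a nitrile, a methoxy group, an amine or a longer chain, since trifluoromethyl and ethyl are the only two seen there. They also leave open whether the result would hold with a shorter chain in place of butyl on the shared core, or with a carboxylic acid on the aromatic carbon where compound 1 and compound 3 differ.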